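This account rests on a few compounds, and the source may have more. Where it says the series, first, only, none or still open, it means among the compounds named here.

Measured so far:
compound 1 `COc1ccc(C(=O)c2ccc3c(ccn3Cc3ccc(C(=O)NO)cc3)c2)cc1OC` gives 18900 nM in an assay on isolated protein for inhibition of polyamine deacetylase HDAC10 (Homo sapiens); on this read-out lower numbers stand for stronger inhibition and higher numbers for weaker inhibition
compound 2 `COc1cc(C(=O)c2ccc3c(ccn3Cc3ccc(C(=O)NO)cc3)c2)cc(OC)c1OC` gives "not determined" (no result reported) in this assay

For the measured compounds named here, compound 1 is the only compound here with a number in this assay, and that number describes weak inhibition. Compound 2 adds a third methoxy group to the same core, but no value was reported for it, so it gives no lead on how the methoxy groups matter.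

Compound 3 `COc1cccc(C(=O)c2ccc3c(ccn3Cc3ccc(C(=O)NO)cc3)c2)c1` carries the change hydrogen in place of methoxy on an aromatic carbon, the group that leaves sitting ortho to a methoxy group and para to a large group. Going by the values given here, no step between measured compounds shows what removing a methoxy does, so the expectation rests on compound 1 alone. The step of a 1.1-fold higher number from compound 1 to compound 3 (0.02 log units; within the scatter) is expected to stay within the usual scatter, with no clear direction. Compound 3 is therefore estimated at 20000 nM in this assay, within a range from 8000 nM to 50000 nM.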

Compound 3, half-maximal inhibitory concentration: 47900 nM
The estimate for compound 3 lay 2.4-fold (0.38 log units) below the measured number; the range from low to high includes it.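

In this assay, for the compounds shown here, the change from 3,4-dimethoxyphenyl to 3-methoxyphenyl gives a 2.5-fold higher number from compound 1 to compound 3 (0.40 log units; beyond the scatter), the first direct comparison at this position. Replacing this methoxy group with hydrogen therefore weakens inhibition modestly, so the group is not interchangeable with hydrogen here, although this rests on a single pair of already weak inhibitors. Nothing available explains why the number moves.

On these data alone, it remains open whether a hydroxyl group, an amine or a fluorine atom at this position would match methoxy, fall to the level of hydrogen or do something else. Compound 2 has no reported number, so these compounds also leave open how a third methoxy group would affect inhibition, and the remaining methoxy group of compound 3 has not been tested by a matching change.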